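This account rests on a few compounds, and the source may have more. Where it says the series, first, only, none or still open, it means among the compounds named here.

In a functional assay on MCF7 cells (Homo sapiens) for antiproliferative activity, read by MTT assay, with a stated time of 72 h (on this read-out lower numbers stand for stronger inhibition and higher numbers for weaker inhibition), compound 1 (`CCN1CCN(c2cc(C)c3cc(NC(=O)c4ccc[nH]4)ccc3n2)CC1`) gives 14700 nM and compound 2 (`CCN1CCN(c2cc(C)c3cc(NC(=O)c4ccccc4)ccc3n2)CC1`) gives 14200 nM. Compound 3 (`CCN1CCN(c2cc(C)c3cc(NC(=O)c4ccc5ccccc5n4)ccc3n2)CC1`) gives 7060 nM, within the scatter of compound 2 and beyond it, on the lower side, against compound 1. Compound 4 (`CCc1ccc(C(=O)Nc2ccc3nc(N4CCN(CC)CC4)cc(C)c3c2)cc1`) differs from compound 3 at one place: 4-ethylphenyl in place of quinolin-2-yl on a carbonyl carbon. The closest guide is a 2.0-fold lower number from compound 2 to compound 3 (0.30 log units; within the scatter), with phenyl replaced by quinolin-2-yl. The other steps, a 2.1-fold lower number from compound 1 to compound 3 (0.32 log units; beyond the scatter) and a 1.0-fold lower number from compound 1 to compound 2 (0.02 log units; within the scatter), are modest at most. Within the data shown here, no measured compound carries an ethyl group. A step beyond the scatter is therefore not expected, and the estimated step is a 1.4-fold higher number from compound 3 to compound 4 (0.15 log units; within the scatter). For compound 4 the estimated value is 10000 nM, with an expected range of 4500 nM to 22000 nM.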

Compound 4, half-maximal inhibitory concentration: 3060 nM
Estimate against measurement, compound 4: 3.3-fold (0.51 log units) above, and the stated range ends above it.
By their numbers in this assay, from the lowest: compound 4; then compounds 3, 2 and 1 (each within the scatter of the next, the first and the last beyond it).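

In this assay, among these compounds, ethyl in place of hydrogen on an aromatic carbon gives a 4.6-fold lower number from compound 2 to compound 4 (0.67 log units; beyond the scatter) and so exceeds every step among the earlier compounds. The group on the carbonyl carbon needs no ring nitrogen or second ring for a lower number: 4-ethylphenyl, with carbon only, gives a 2.3-fold lower number from compound 3 to compound 4 (0.36 log units; beyond the scatter) and also a 4.8-fold lower number from compound 1 to compound 4 (0.68 log units; beyond the scatter) in this series. No supporting data explain this result. From the compounds shown here alone, whether methyl, a longer chain or an amine on that phenyl ring would match ethyl remains open.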